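Carboxy chain in place of dimethylaminophenyl on the amide

The compounds below may be only part of what the source reports. "The series", "measured", "known", "first", "only" and "open" are said of these compounds alone.

Compound 1 `CN(C)c1ccc(C(=O)N2CCC(NS(=O)(=O)c3cc(S(=O)(=O)c4ccccc4)ccc3C(F)(F)F)CC2)cc1` gives 50000 nM in a physicochemical assay for solubility (a higher number here means a more soluble compound, a lower number a less soluble compound), the higher of the two numbers; compound 2 `O=C(O)c1ccc(N2CCC(NS(=O)(=O)c3cc(S(=O)(=O)c4ccccc4)ccc3C(F)(F)F)CC2)cc1` gives 25000 nM. The step of a 2.0-fold lower number from compound 1 to compound 2 (0.30 log units; within the scatter) is the only measured one and it brings in a carboxy group, as does the change to compound 3 `O=C(O)CCCC(=O)N1CCC(NS(=O)(=O)c2cc(S(=O)(=O)c3ccccc3)ccc2C(F)(F)F)CC1`: 3-carboxypropyl in place of 4-(dimethylamino)phenyl on a carbonyl carbon. Within the data shown here, no step bears on the chain itself. With the carboxy step within the scatter, no movement beyond the scatter is expected, no change at the digits printed from compound 1 to compound 3 (within the scatter). Compound 3 is therefore estimated at 50000 nM, with a range of 15000 nM to 160000 nM.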

Compound 3, solubility: 50000 nM
For compound 3 middle estimate and measured number coincide at the digits printed; measured number inside the range.
By their numbers in this assay, from the lowest: compounds 2, 1 and 3 (each within the scatter of the next).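

In this assay the 3-carboxypropyl chain, with no ring, in place of 4-(dimethylamino)phenyl on the carbonyl carbon gives no change at the digits printed from compound 1 to compound 3 (within the scatter) and so leaves the number within the scatter. Set against the 4-carboxyphenyl group, the same chain gives a 2.0-fold higher number from compound 2 to compound 3 (0.30 log units; within the scatter) and so the three compounds cannot be ranked in this assay. No supporting data bear on this result.

Open: whether a longer chain, or a methyl ester or primary amine in place of the carboxylic acid, would stay within the scatter of these numbers or move beyond it.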